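The source may hold more compounds than are shown below. What is called first, only, known or untested is meant among the compounds shown, and "the series" means these compounds.

Working notes on the series. In an assay on cell membranes for displacement of a labelled ligand from Neuronal acetylcholine receptor; alpha4/beta2 (Rattus norvegicus) (on this read-out lower numbers stand for stronger inhibition and higher numbers for weaker inhibition), compound 1 `COc1ccc(Nc2cncc(N3CC4CC(C3)N4)c2)cc1` gives 0.0598 nM and compound 2 `Clc1ccc(Nc2cncc(N3CC4CC(C3)N4)c2)cc1` gives 0.118 nM. Among the measured compounds shown here, compound 2 stands at the highest of the two numbers so far, though its only neighbour is compound 1, and the step of a 2.0-fold higher number from compound 1 to compound 2 (0.30 log units; within the scatter) leaves the two within the scatter of this assay. Compound 3 `Oc1ccc(Nc2cncc(N3CC4CC(C3)N4)c2)cc1` has not yet been measured; it differs from compound 2 by hydroxy in place of chloro on an aromatic carbon. For the measured compounds named here, only one measured step bears on this change, a 2.0-fold higher number from compound 1 to compound 2 (0.30 log units; within the scatter), which exchanged one small group at the same aromatic carbon for another without moving beyond the scatter. On that basis the exchange of chloro for hydroxy is expected to give at most a small step, a 1.3-fold lower number from compound 2 to compound 3 (0.12 log units; within the scatter), with no direction that can be read off the data. Compound 3 is therefore estimated at 0.09 nM in this assay, with a range from 0.03 nM to 0.27 nM.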

Compound 3, inhibition constant: 0.342 nM
Compound 3: middle estimate off by 3.8-fold (0.58 log units), on the low side; measured number above the stated range.
By their numbers in this assay, from the lowest: compounds 1 and 2 (each within the scatter of the next); then compound 3.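

In this assay, among the compounds shown here, the 4-hydroxyphenyl compound is the first to separate from another compound: a 2.9-fold higher number from compound 2 to compound 3 (0.46 log units; beyond the scatter) and a 5.7-fold higher number from compound 1 to compound 3 (0.76 log units; beyond the scatter) are modest, but both lie beyond the scatter. The aromatic carbon para to a large group therefore does not accept every small group equally, as the step between chloro and methoxy alone could not show. Removing only the methyl from the oxygen is enough to move the number beyond the scatter, so an oxygen at this position does not by itself preserve the result of compound 1. Nothing available accounts for this step. On these data alone, whether an amino group here would stay with hydroxy or fall with chloro and methoxy remains open. So does the outcome for a longer chain on the oxygen, such as ethoxy.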